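Shortening the hydroxypropyl chain at the amine of compound 3

A few compounds are considered here, and "the series" means these few. Any claim that something is new, unique, unknown or untested is made for them only; others in the source may bear on it.

Compound 3 `OCCC(NC1CCN(CCCc2c[nH]c3ccc(-n4cnnc4)cc23)CC1)c1ccccc1` holds the highest position among the three measured compounds in a functional assay on CHO cells for activation of 5-hydroxytryptamine receptor 1D (Homo sapiens), read by GTPgammaS binding (a higher number here means a larger maximal response, a lower number a smaller maximal response), where compound 3 gives 100%. Its nearest neighbour is compound 1 `O[C@@H]1Cc2ccccc2[C@H]1NC1CCN(CCCc2c[nH]c3ccc(-n4cnnc4)cc23)CC1`, which in this assay gives 75%, and the furthest is compound 2 `c1ccc2c(c1)CCC2NC1CCN(CCCc2c[nH]c3ccc(-n4cnnc4)cc23)CC1`, which gives 68%. The step from compound 3 to compound 4 `C[C@@H](NC1CCN(CCCc2c[nH]c3ccc(-n4cnnc4)cc23)CC1)c1ccccc1` is this: 1-phenylethyl in place of 3-hydroxy-1-phenylpropyl on an amine nitrogen. Within the data shown here, two measured steps bear on it. Replacing the indane groups with the 3-hydroxy-1-phenylpropyl group gave a number 25 percentage points higher from compound 1 to compound 3 (beyond the scatter) and a number 32 percentage points higher from compound 2 to compound 3 (beyond the scatter), both beyond the scatter, so the open-chain group carrying the hydroxyl is linked with the largest maximal response seen. The loss of the hydroxyl on its own, however, gave only a number 7 percentage points lower from compound 1 to compound 2 (within the scatter), a difference within the scatter. Compound 4 keeps the open-chain phenyl-bearing group but gives up the hydroxyl and two chain carbons, so a moderate downward step is expected, written as a number 15 percentage points lower from compound 3 to compound 4 (beyond the scatter). For compound 4 an efficacy of 85% is estimated, with a range from 65% to 100%.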

Compound 4, largest response reached (reported as efficacy), in percent of the reference or control that the assay uses: 90%
Compound 4: the middle estimate sits 5 percentage points below what was measured, within the range that was stated.
By their numbers in this assay, from the lowest: compounds 2 and 1 (each within the scatter of the next); then compounds 4 and 3 (each within the scatter of the next).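

In this assay, the open-chain group at this amine does not need its hydroxyl to hold a high maximal response, since 1-phenylethyl in place of 3-hydroxy-1-phenylpropyl gives a number 10 percentage points lower from compound 3 to compound 4 (within the scatter), even though the entering group has 0 hydrogen-bond donors and 0 hydrogen-bond acceptors. The gap to the indane-bearing compounds also survives without that hydroxyl, with a number 22 percentage points higher from compound 2 to compound 4 (beyond the scatter) and a number 15 percentage points higher from compound 1 to compound 4 (beyond the scatter), so among these four compounds both open-chain groups stand apart from both 2,3-dihydro-1H-inden-1-yl groups, and no compound goes against this. No measurement is available here that explains these differences.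

The step from compound 3 to compound 4 changes the hydroxyl and the chain together, so a 1-phenylpropyl group, which would keep the longer chain without the hydroxyl, is what could tell these two changes apart. Also open, on these data alone, are the opposite configuration of the 1-phenylethyl group and whether a 3-amino-1-phenylpropyl group, with an amine in place of the hydroxyl, would fall within the same range.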